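A Halogenated Aryl Swap on an Inactive Pair

The compounds below may be only part of what the source reports. "The series", "measured", "known", "first", "only" and "open" are said of these compounds alone.

The two measured compounds are compound 1 `Cc1ccc(-n2nncc2CN2C(=O)C3(C(C#N)=C(N)Oc4c3c3nc5ccccc5nc3c3ccccc43)c3ccccc32)cc1Cl` and compound 2 `CCc1cccc(C)c1-n1nncc1CN1C(=O)C2(C(C#N)=C(N)Oc3c(N)cc4nc5ccccc5nc4c32)c2ccccc21`. In a functional assay on HCT-116 cells (Homo sapiens) for antiproliferative activity, read by MTT assay, with a stated time of 48 h (a lower number here means a stronger inhibitor, a higher number a weaker inhibitor), compound 1 reaches only the limit of > 50000 nM. Compound 2 likewise reports only the limit of > 50000 nM in this assay. Both values sit at the limit of > 50000 nM in this assay, at which 2 of the 2 values shown sit, so compound 2 stands at the edge of what the measurement can report. Compound 3 `N#CC1=C(N)Oc2c(N)cc3nc4ccccc4nc3c2C12C(=O)N(Cc1cnnn1-c1c(Cl)cc(Cl)cc1Cl)c1ccccc12` carries 2,4,6-trichlorophenyl in place of 2-ethyl-6-methylphenyl on an aromatic nitrogen. Within the data shown here, no measured step exists to guide expectation, so the step that the limit leaves unreadable from compound 2 to compound 3 is expected to stay within the scatter in this assay. Compound 3 is therefore estimated at 70000 nM, with a range from 20000 nM to 250000 nM.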

Compound 3, half-maximal inhibitory concentration: 12100 nM
Compound 3: the middle estimate sits 5.8-fold (0.76 log units) above what was measured; the whole stated range lies above it.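

In this assay, placing 2,4,6-trichlorophenyl in place of 2-ethyl-6-methylphenyl on the aromatic nitrogen gives an at least 4.1-fold lower number from compound 2 to compound 3 (0.61 log units; beyond the scatter). Among these compounds, this is the first readable sign that a change at this position can move the result, which the earlier compounds could not show. As far as these compounds go, the true size of the step stays unknown because compound 2 is a limit, not a number: the limit of > 50000 nM in this assay, at which 2 of the 3 values shown sit.

The compounds shown leave open whether the chlorine atoms alone account for the step. They also leave open how a single chlorine, a methoxy group or an amine on this phenyl ring would fare.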